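The compounds below may be only part of what the source reports. "The series", "measured", "known", "first", "only" and "open" are said of these compounds alone.

Measured in a functional assay (plasma) for inhibition, with Homo sapiens as the target; on this read-out higher numbers stand for weaker inhibition and lower numbers for stronger inhibition:
- compound 1 `O=C(O)CCC/C=C\C[C@H]1/C(=N/OCc2ccc(C(F)(F)F)cc2)CC[C@@H]1NS(=O)(=O)c1ccc(Cl)cc1`: 200 nM
- compound 2 `Cc1ccc(S(=O)(=O)N[C@H]2CC/C(=N\OCC3CCCCC3)[C@@H]2C/C=C\CCCC(=O)O)cc1`: 600 nM
- compound 3 `O=C(O)CCC/C=C\C[C@H]1/C(=N/OCC2CCCCC2)CC[C@@H]1NS(=O)(=O)c1ccc(F)cc1`: 1800 nM

Compound 3, at 1800 nM, has the highest number of the three and so the weakest inhibition. The next entry is compound 4 `O=C(O)CCC/C=C\C[C@H]1/C(=N/OCC2CCCCC2)CC[C@@H]1NS(=O)(=O)c1ccc(Cl)cc1`, which differs from compound 3 as follows: chloro in place of fluoro on an aromatic carbon. In words, this is chloro in place of fluoro on an aromatic carbon.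

Among the measured compounds shown here, no measured step compares chloro and fluoro directly. The nearest evidence is a 3.0-fold higher number from compound 2 to compound 3 (0.48 log units; beyond the scatter), a modest step with fluoro in place of methyl on an aromatic carbon. Compound 1 carries the same 4-chlorophenyl group and gives 200 nM, but it also differs elsewhere, so it offers only loose support.

A modest move to a lower number is therefore expected in this assay, of about the size of the methyl-to-fluoro step but in reverse. The estimated change is a 2.6-fold lower number from compound 3 to compound 4 (0.41 log units; beyond the scatter). The estimate for compound 4 is 700 nM, with an expected range of 250 nM to 1800 nM.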

Compound 4, half-maximal inhibitory concentration: 1700 nM
Estimate against measurement, compound 4: 2.4-fold (0.39 log units) below; measured number inside the range.
By their numbers in this assay, from the lowest: compound 1; then compound 2; then compounds 4 and 3 (each within the scatter of the next).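

In this assay, a 1.1-fold lower number from compound 3 to compound 4 (0.02 log units; within the scatter), so with the cyclohexyl group in place, 4-fluorophenyl and 4-chlorophenyl on the sulfonyl cannot be told apart. Methyl at this aromatic carbon now stands apart from both halogens: a 3.0-fold higher number from compound 2 to compound 3 (0.48 log units; beyond the scatter), and likewise a 2.8-fold higher number from compound 2 to compound 4 (0.45 log units; beyond the scatter). With the (4-chlorophenyl)sulfonyl group held fixed, an 8.5-fold higher number from compound 1 to compound 4 (0.93 log units; beyond the scatter) shows that the change from 4-(trifluoromethyl)phenyl to cyclohexyl also moves the number beyond the scatter. No supporting measurement is available to explain these steps.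

Still open, from the compounds shown here alone, is whether a methoxy group or an amine at this aromatic carbon would fall with methyl or with the two halogens. The compounds shown also leave open whether 4-(trifluoromethyl)phenyl would keep its advantage over cyclohexyl with fluoro or methyl on the sulfonyl aryl ring.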